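Notes on the step from compound 3 to compound 4

This account rests on a few compounds, and the source may have more. Where it says the series, first, only, none or still open, it means among the compounds named here.

In an ADME assay on cells (Hepatocyte, Rattus norvegicus) for pharmacokinetics, read by LC-MS, with a stated time of 90 min, tested at 1 uM (a higher number here means faster removal of the compound, a lower number slower removal), compound 1 `COC(=O)N(CCO)c1c(N)nc(-c2nn(Cc3ccccc3F)c3ncccc23)nc1N` gives 61.7 mL/min/kg and compound 2 `COC(=O)N(Cc1ccc(F)cc1)c1c(N)nc(-c2nn(Cc3ccccc3F)c3ncccc23)nc1N` gives 40 mL/min/kg. Compound 3 `Nc1nc(-c2nn(Cc3ccccc3F)c3ncccc23)nc(N)c1NC(=O)OC1COC1` stands lowest of the three at 1.67 mL/min/kg, clearly apart from both others. Compound 4 `Nc1nc(-c2nn(Cc3ccccc3F)c3ncccc23)nc(N)c1N1CCOC1=O` is not yet measured. Its change from compound 3 is 2-oxo-1,3-oxazolidin-3-yl in place of (((oxetan-3-yl)oxy)carbonyl)amino on an aromatic carbon.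

Going by the values given here, two measured steps bear on this. The first is a 37-fold lower number from compound 1 to compound 3 (1.57 log units; beyond the scatter), at the same aromatic carbon. The second is a 1.5-fold lower number from compound 1 to compound 2 (0.19 log units; within the scatter), on the chain of the amide-type nitrogen, and it stays within the scatter. Among the compounds with values here, the low number has been seen only with the (((oxetan-3-yl)oxy)carbonyl)amino group of compound 3, and that group leaves. Within the data shown here, no measured compound carries the 2-oxo-1,3-oxazolidin-3-yl group, so there is no direct reading for it. The expected step is a 7.2-fold higher number from compound 3 to compound 4 (0.86 log units; beyond the scatter), an upward estimate with wide uncertainty. For compound 4 the estimate is 12 mL/min/kg, with an expected range of 2.5 mL/min/kg to 50 mL/min/kg.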

Compound 4, clearance: 6.67 mL/min/kg
For compound 4 the middle estimate is 1.8-fold (0.26 log units) above the measured one; measured number inside the range.
By their numbers in this assay, from the lowest: compound 3; then compound 4; then compounds 2 and 1 (each within the scatter of the next).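

At the aromatic carbon ortho to two amino groups, a low number in this assay is not confined to the (((oxetan-3-yl)oxy)carbonyl)amino group: the 2-oxo-1,3-oxazolidin-3-yl group gives a 9.3-fold lower number from compound 1 to compound 4 (0.97 log units; beyond the scatter), although a 4.0-fold higher number from compound 3 to compound 4 (0.60 log units; beyond the scatter). A low number at this position therefore does not require the hydrogen-bond donor of the leaving group, since the entering group has none. No supporting measurement bears on the reason for either step.

The step from the oxetane carbamate to the cyclic one changes several features together, so the part played by the oxetane ring, the amide hydrogen and ring closure cannot be separated. A methoxycarbonylamino group, which keeps the amide hydrogen without the oxetane ring, and a six-membered cyclic carbamate at this carbon would help to separate them.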